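This account rests on a few compounds, and the source may have more. Where it says the series, first, only, none or still open, it means among the compounds named here.

Measured so far in a functional assay on BJAB cells (Homo sapiens) for antiproliferative activity, with a stated time of 4 days; a higher number here means that more compound is needed for the effect, a lower number that less compound is needed:
- compound 1 `COC(=O)c1c(Cc2ccccc2[N+](=O)[O-])c(C)nn1-c1nc(-c2ccc(Cl)c(Cl)c2)cs1` gives 377000 nM
- compound 2 `Cc1nn(-c2nc(-c3ccc(Cl)c(Cl)c3)c(SC(C)C)s2)c(C(=O)O)c1-c1cc(C#N)cc(C(F)(F)F)c1` gives 3600 nM
- compound 3 `Cc1c(-c2cc(Cl)cc(Cl)c2)c(C(=O)O)nn1-c1nc(-c2ccncc2)c(SC(C)C)s1` gives "not active" (no number reported)

Compound 2 stands lowest of the two compounds with a number; the nearest, compound 1, sits far beyond the scatter at a much higher value, and compound 3 gives no number at all. Compound 4 `Cc1cc(Cl)cc(-c2c(C)nn(-c3nc(-c4ccc(Cl)c(Cl)c4)c(SC(C)C)s3)c2C(=O)O)c1` has not yet been measured. It differs from compound 2 in one place: 3-chloro-5-methylphenyl in place of 3-cyano-5-(trifluoromethyl)phenyl on an aromatic carbon. For the measured compounds named here, no measured pair shows this exact change, so its effect is uncertain. In this assay the expected step of a 2.2-fold higher number from compound 2 to compound 4 (0.35 log units; beyond the scatter) is a moderate rise in the number needed, somewhat beyond the scatter, since compound 2 is the only close anchor. Compound 4 is therefore estimated at 8000 nM, with a range from 2000 nM to 40000 nM.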

Compound 4, half-maximal effective concentration: 663 nM
Compound 4: middle estimate off by 12-fold (1.08 log units), on the high side, outside the stated range (below it).
By their numbers in this assay, from the lowest: compound 4; then compound 2; then compound 1.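

In this assay, putting 3-chloro-5-methylphenyl in place of 3-cyano-5-(trifluoromethyl)phenyl gives a 5.4-fold lower number from compound 2 to compound 4 (0.73 log units; beyond the scatter), a modest step. So the number responds to the aryl group at this position, next to the ring atom that bears a carboxy group, and a nitrile and trifluoromethyl pair is not needed for activity here. No measurement offered here explains the drop. Going by these compounds, both ring substituents change together, so the share of each remains unknown. On these data alone, whether an amine or a longer chain on this ring would lower the number further also stays open.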